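The compounds below may be only part of what the source reports. "The series", "measured", "known", "first", "only" and "open" are said of these compounds alone.

Three compounds have been measured so far in a functional assay on NCI-H1792 cells (Homo sapiens) for cytotoxicity, read by resazurin assay, with a stated time of 72 h (on this read-out higher numbers stand for weaker inhibition and lower numbers for stronger inhibition), with these results:

Compound 1 `O=C(/C=C/c1ccc(OCCCCCO[N+](=O)[O-])c(O)c1)OCCCCCO[N+](=O)[O-]` gives > 50000 nM as a limit of the assay, not a number
Compound 2 `COc1cc(/C=C/C(=O)OCCCCCO[N+](=O)[O-])ccc1O` gives 13000 nM as its value
Compound 3 `O=C(/C=C/c1ccc(O)c(O)c1)OCc1c(-c2ccccc2)no[n+]1[O-]` gives 3780 nM as its value

Compound 3 at 3780 nM holds the lower of the two actual numbers. Compound 2 at 13000 nM lies higher, and this gap is beyond the usual scatter. Compound 1 shows only a limit, the > 50000 nM noted above.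

Compound 4 `COc1cc(/C=C/C(=O)OCc2c(-c3ccccc3)no[n+]2[O-])ccc1O` differs from compound 3 in one place (methyl in place of hydrogen on an oxygen on an aromatic ring), with methyl in place of hydrogen on an oxygen on an aromatic ring. This turns 3,4-dihydroxyphenyl into 4-hydroxy-3-methoxyphenyl.

Among the measured compounds shown here, no measured pair shows this change on its own. Compound 2 at 13000 nM carries the same 4-hydroxy-3-methoxyphenyl group and has a higher number than compound 3 at 3780 nM in this assay but also differs elsewhere in its structure, which makes it only a weak hint. A small move towards weaker inhibition, about the size of the scatter, is therefore expected. The estimated step is a 1.6-fold higher number from compound 3 to compound 4 (0.20 log units; within the scatter) on this reasoning. For compound 4 the estimate is 6000 nM with an expected range from 2000 nM to 18000 nM in this assay.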

Compound 4, half-maximal inhibitory concentration: 11100 nM
Beside the measured number, compound 4's estimate is 1.9-fold (0.27 log units) below it, within the range that was stated.
By their numbers in this assay, from the lowest: compound 3; then compounds 4 and 2 (each within the scatter of the next). At a limit, above all of these: compound 1.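

Among the compounds shown here, the pair gives the first direct reading of this change in this assay: with the rest of the structure held the same, methyl in place of hydrogen on an oxygen on an aromatic ring, which turns 3,4-dihydroxyphenyl into 4-hydroxy-3-methoxyphenyl, gives a 2.9-fold higher number from compound 3 to compound 4 (0.47 log units; beyond the scatter). The earlier hint came from compound 2, which also differs elsewhere, whereas this pair isolates the change and shows that this single methyl moves the read-out towards weaker inhibition by a modest step beyond the scatter. The data shown give no reason for this step, and one pair cannot separate the loss of the hydroxy hydrogen from the gain of the methyl.

Only one replacement on this oxygen appears here, leaving open whether an ethyl group, a longer chain or an acetyl group there would give a similar number or a different one. Also open, going by these compounds, is whether the same step would appear on a compound carrying the ester of compound 2 rather than the ester shared by this pair.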